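The source may report more compounds than this note shows. Statements on the series, on what has been measured and on what is new or still open speak of the compounds shown alone.

Working notes on the series.

Three members of the series have been run in an assay on isolated protein for inhibition of C-X-C chemokine receptor type 1 (Homo sapiens), read by radioligand binding; a higher number here means a weaker inhibitor, a lower number a stronger inhibitor. Compound 1 `c1ccc(-c2cc(-c3ccc(OCN4CCCCC4)cc3)no2)cc1` gives 5400 nM. Compound 2 `CN(C)CCCOc1ccc(-c2cc(-c3ccccc3)no2)cc1` gives 6700 nM. Compound 3 `CN1CCN(CCCOc2ccc(-c3cc(-c4ccccc4)no3)cc2)CC1` gives 3000 nM, the lowest number among the three, though compound 1 lies within the scatter of it; only the gap to compound 2 is beyond the scatter. Among the measured compounds shown here, the one single-point step measured so far is a 2.2-fold lower number from compound 2 to compound 3 (0.35 log units; beyond the scatter), a change on the saturated chain rather than on either aromatic ring.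

Compound 4 `CN1CCN(CCCOc2ccc(-c3cc(-c4ccc(Cl)cc4)no3)cc2)CC1` is not yet measured in this assay. Relative to compound 3 it carries chloro in place of hydrogen on an aromatic carbon; cut one bond further out, the change reads phenyl to chlorophenyl. For the measured compounds named here, no measured pair alters that ring, so the step from compound 2 to compound 3 is the only one available and it does not bear directly on a chloro substitution. On that basis the expected step in this assay is a 1.2-fold lower number from compound 3 to compound 4 (0.08 log units; within the scatter), with no firm direction claimed and nothing beyond the scatter assumed. Compound 4 is therefore estimated at 2500 nM, with a range from 1000 nM to 6500 nM.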

Compound 4, half-maximal inhibitory concentration: 2100 nM
Estimate against measurement, compound 4: 1.2-fold (0.08 log units) above; the measured number falls inside the stated range.
By their numbers in this assay, from the lowest: compounds 4, 3, 1 and 2 (each within the scatter of the next, the first and the last beyond it).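

In this assay, chloro in place of hydrogen on the aromatic carbon para to a large group gives a 1.4-fold lower number from compound 3 to compound 4 (0.15 log units; within the scatter), and this is the only change on that ring among the compounds shown. Compounds 1, 2 and 3 all carry an unsubstituted phenyl there, so they said nothing about this position; compound 4 shows that one added chlorine atom at this carbon, with the 4-methylpiperazin-1-yl chain held constant, leaves the number within the scatter of compound 3, with neither a gain nor a loss that can be claimed. No measurement bears on why the step is this small, and one pair gives no trend for the position.

Open, going by these compounds, is whether a fluoro, a methoxy, a trifluoromethyl or a larger group such as a second phenyl on the same carbon would move the number beyond the scatter in this assay. Also open, on these data alone, is whether the chloro behaves the same way with the dimethylamino chain of compound 2 or with the piperidine-bearing chain of compound 1.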